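Aryl and alkynyl substituents on a shared nucleoside core

The compounds below may be only part of what the source reports. "The series", "measured", "known", "first", "only" and "open" are said of these compounds alone.

Measured compounds:
- compound 1 `CCCCC#Cc1cc([C@@H]2O[C@H](CO)[C@@H](O)[C@H]2O)n2ncnc(N)c12` — 1700 nM
- compound 2 `Nc1ncnn2c([C@@H]3O[C@H](CO)[C@@H](O)[C@H]3O)cc(C#CC3CC3)c12` — 80 nM
- compound 3 `COc1ccc(-c2cc([C@@H]3O[C@H](CO)[C@@H](O)[C@H]3O)n3ncnc(N)c23)cc1` — 69300 nM

All three share one core and differ only in the substituent on an aromatic carbon of the five-membered ring. In a functional assay on NCI-H460 cells (Homo sapiens) for antiproliferative activity, with a stated time of 72 h (a lower number here means a stronger inhibitor, a higher number a weaker inhibitor), compound 3 gives the highest number of the three: compound 1 sits a 41-fold higher number from compound 1 to compound 3 (1.61 log units; beyond the scatter) and compound 2 sits an 870-fold higher number from compound 2 to compound 3 (2.94 log units; beyond the scatter). The two alkynes are far apart from each other as well, with a 21-fold lower number from compound 1 to compound 2 (1.33 log units; beyond the scatter).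

Compound 4 `Nc1ncnn2c([C@@H]3O[C@H](CO)[C@@H](O)[C@H]3O)cc(-c3ccsc3)c12` is not yet measured. Its difference from compound 3 is thiophen-3-yl in place of 4-methoxyphenyl on an aromatic carbon. For the measured compounds named here, no measured step exchanges one aromatic group for another, so the two large steps into compound 3 bear on it only indirectly: both show that the 4-methoxyphenyl compound is the weakest point of the series, and that a change at this carbon can shift this assay by a large amount. The direction of an aryl-for-aryl swap is not settled by any measured pair.

On that basis compound 4 is expected to give a lower number than compound 3, estimated as a 2.8-fold lower number from compound 3 to compound 4 (0.44 log units; beyond the scatter), with a wide range. The estimate for compound 4 in this assay is 25000 nM, between 5000 nM and 120000 nM.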

Compound 4, half-maximal inhibitory concentration: 35600 nM
Beside the measured number, compound 4's estimate is 1.4-fold (0.15 log units) below it, within the range that was stated.
By their numbers in this assay, from the lowest: compound 2; then compound 1; then compounds 4 and 3 (each within the scatter of the next).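

In this assay, the exchange of one aromatic group for another at this carbon gives a 1.9-fold lower number from compound 3 to compound 4 (0.29 log units; within the scatter), so thiophen-3-yl, with its five-membered aromatic ring and sulfur, and 4-methoxyphenyl, with its six-membered carbon ring and methoxy group, are not told apart here. The large gap to the alkynes is therefore not peculiar to 4-methoxyphenyl: it recurs with a second aromatic group, as a 450-fold higher number from compound 2 to compound 4 (2.65 log units; beyond the scatter) and a 21-fold higher number from compound 1 to compound 4 (1.32 log units; beyond the scatter), and among these four compounds, neither aromatic group comes near either alkyne. Nothing available here accounts for these differences.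

Open, going by these compounds, is whether the triple bond itself matters or only the group it carries, which a saturated hexyl chain or a cyclopropyl group placed directly on this carbon would test. Also open, on these data alone, is how far the alkyne end can vary beyond butyl and cyclopropyl, for instance with a phenyl ring or a hydroxymethyl group on the triple bond, and whether an amine on the aromatic ring would change the aryl result.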